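Carboxymethyl to (carboxymethyl)sulfanyl: working notes

This account rests on a few compounds, and the source may have more. Where it says the series, first, only, none or still open, it means among the compounds named here.

Compound 3 `CC(C)(C)C(=O)CN1C(=O)N(CC(=O)Nc2cccc(CC(=O)O)c2)C(=O)N(C2CCCCCC2)c2ccccc21` gives 43.7 nM in a functional assay on stomach for antagonist activity at Gastrin/cholecystokinin type B receptor (Rattus norvegicus) (on this read-out lower numbers stand for tighter binding and higher numbers for weaker binding), the highest number among the three measured. Compound 2 `CC(C)(C)C(=O)CN1C(=O)N(CC(=O)Nc2cccc(CCC(=O)O)c2)C(=O)N(C2CCCCC2)c2ccccc21`, at 26.3 nM in this assay, lies within the scatter of compound 3, whereas compound 1 `CNc1cccc(NC(=O)CN2C(=O)N(CC(=O)C(C)(C)C)c3ccccc3N(C3CCCCC3)C2=O)c1`, at 19.5 nM, lies beyond it. Compound 4 `CC(C)(C)C(=O)CN1C(=O)N(CC(=O)Nc2cccc(SCC(=O)O)c2)C(=O)N(C2CCCCCC2)c2ccccc21` has not been measured; it differs from compound 3 in one place: (carboxymethyl)sulfanyl in place of carboxymethyl on an aromatic carbon. Among the compounds with values here, the only measured step at the same place is a 1.3-fold higher number from compound 1 to compound 2 (0.13 log units; within the scatter), which exchanges a methylamino for a 2-carboxyethyl and stays within the scatter. Within the data shown here, no measured pair covers the carboxymethyl to (carboxymethyl)sulfanyl exchange itself, and the shared core is unchanged, so a number close to that of compound 3 is expected, in either direction but not beyond the scatter. Compound 4 is therefore estimated at 40 nM in this assay, with a range from 15 nM to 110 nM. That estimate corresponds to an expected step of a 1.1-fold lower number from compound 3 to compound 4 (0.04 log units; within the scatter).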

Compound 4, dissociation constant: 4.47 nM
The estimate for compound 4 lay 8.9-fold (0.95 log units) above the measured number; the whole stated range lies above it.
By their numbers in this assay, from the lowest: compound 4; then compounds 1, 2 and 3 (each within the scatter of the next, the first and the last beyond it).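

In this assay, (carboxymethyl)sulfanyl in place of carboxymethyl on this aromatic carbon gives a 9.8-fold lower number from compound 3 to compound 4 (0.99 log units; beyond the scatter) and so moves the number beyond the scatter. The only earlier step at this place, a 1.3-fold higher number from compound 1 to compound 2 (0.13 log units; within the scatter), stayed within the scatter, so the series had not yet shown that this position responds to a change in its substituent, and here a small exchange that adds one sulfur to the chain is enough. Nothing at hand bears on why the number moves.

As far as these compounds go, it stays open whether the sulfur itself or the longer reach of the chain carries the step, which a (carboxymethyl)oxy group or a 3-carboxypropyl chain on the same carbon would help to separate. Also open, from the compounds shown here alone, is whether the carboxylic acid is needed at the chain end, or whether a primary amide or a methyl ester there keeps the number.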